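The source may hold more compounds than are shown below. What is called first, only, known or untested is meant among the compounds shown, and "the series" means these compounds.

Compound 1, `O=C(NCc1ccc(S(=O)(=O)c2ccccc2)cc1)N1Cc2cccnc2C1`, in an assay on isolated protein for inhibition of Nicotinamide phosphoribosyltransferase (Homo sapiens), read by mass spectrometry, with stated times of 15 min and 30 min (a lower number here means a stronger inhibitor, a higher number a weaker inhibitor), compound 1 gives 60 nM.
Compound 2, `O=C(NCc1ccc(S(=O)(=O)C2CCCOC2)cc1)N1Cc2ccncc2C1`, in this assay compound 2 gives 44 nM.

Compound 2 has the smaller of the two numbers shown, but its gap to compound 1 lies within the usual scatter of repeated measurements, so the two are not distinguished by these data and neither can be called the stronger inhibitor. Compound 3, `O=C(NCc1ccc(S(=O)(=O)N2CCC(N3CCCC3)CC2)cc1)N1Cc2ccncc2C1`, has not yet been measured in this assay. It differs from compound 2 at a single place: 4-(pyrrolidin-1-yl)piperidin-1-yl in place of oxan-3-yl on a sulfonyl sulfur. Among the measured compounds shown here, no step between measured compounds is on record that would show how a change at the sulfonyl sulfur shifts the read-out; the only comparison available, compound 1 against compound 2, shows that exchanging one sulfonyl substituent for another left the number essentially unchanged. On that basis the step from compound 2 to compound 3 is expected to be small and is not expected to reach beyond the scatter in either direction, the estimated step being a 1.8-fold higher number from compound 2 to compound 3 (0.26 log units; within the scatter). Compound 3 is therefore estimated to give 80 nM, with an expected range from 25 nM to 300 nM.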

Compound 3, half-maximal inhibitory concentration: 7.4 nM
Estimate against measurement, compound 3: 11-fold (1.03 log units) above; the measured number lies below the stated range.
By their numbers in this assay, from the lowest: compound 3; then compounds 2 and 1 (each within the scatter of the next).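

In this assay, among the compounds shown here, the exchange of oxan-3-yl for 4-(pyrrolidin-1-yl)piperidin-1-yl on the sulfonyl sulfur is a 5.9-fold lower number from compound 2 to compound 3 (0.77 log units; beyond the scatter) and is the first step on record at this position, and it lies beyond the scatter. It shows that the read-out responds to the group on the sulfonyl sulfur, at least for this change on the core of compound 2, something compound 1 and compound 2 could not show, as that pair differs in more than one place. The step also marks a swap of one ring for two, with an oxygen leaving and two nitrogens entering, but no measurement here ties it to any one of these features.

Going by these compounds, it remains open whether the piperidin-1-yl ring alone would give a similar number, or whether the pyrrolidin-1-yl ring could be replaced on it by a dimethylamino group, a morpholine or a carboxylic acid without losing the step. The compounds also leave open whether 4-(pyrrolidin-1-yl)piperidin-1-yl would give a step of similar size on the core of compound 1.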